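This account rests on a few compounds, and the source may have more. Where it says the series, first, only, none or still open, it means among the compounds named here.

In a functional assay on CCRF-CEM cells (Homo sapiens) for antiproliferative activity (a lower number here means a stronger inhibitor, a higher number a weaker inhibitor), compound 1 `COc1cc(C(=O)c2sc(-c3cccc([N+](=O)[O-])c3)cc2N)cc(OC)c1OC` gives 5.9 nM and compound 2 `CCOc1ccc(-c2cc(N)c(C(=O)c3cc(OC)c(OC)c(OC)c3)s2)cc1` gives 270 nM, so compound 2 holds the higher of the two numbers. Compound 3 `COc1cc(C(=O)c2sc(-c3ccc(C(F)(F)F)cc3)cc2N)cc(OC)c1OC` departs from compound 2 by trifluoromethyl in place of ethoxy on an aromatic carbon. For the measured compounds named here, only one measured step bears on this: a 46-fold higher number from compound 1 to compound 2 (1.66 log units; beyond the scatter), a large step with 4-ethoxyphenyl in place of 3-nitrophenyl. Going by the values given here, no measured compound carries trifluoromethyl, so a moderate step towards a lower number is expected, short of the full size of that step. Compound 3 is estimated at 60 nM, with an expected range of 12 nM to 300 nM, an expected 4.5-fold lower number from compound 2 to compound 3 (0.65 log units; beyond the scatter).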

Compound 3, half-maximal inhibitory concentration: 270 nM
Compound 3: the middle estimate sits 4.5-fold (0.65 log units) below what was measured, within the range that was stated.
By their numbers in this assay, from the lowest: compound 1; then compounds 2 and 3 (each within the scatter of the next).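

At this position, para to a large group, trifluoromethyl in place of ethoxy leaves the number unchanged in this assay (no change at the digits printed from compound 2 to compound 3 (within the scatter)), so the hydrogen-bond acceptor that ethoxy carries and trifluoromethyl lacks makes no visible difference in this pair. The gap to the 3-nitrophenyl compound recurs with 4-(trifluoromethyl)phenyl (a 46-fold higher number from compound 1 to compound 3 (1.66 log units; beyond the scatter)), so it is not peculiar to ethoxy. No evidence is available to explain either step. Still open, on these data alone, is whether nitro at this para place would match compound 1, and how an amine or a carboxylic acid there would read.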